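Halogen swap on the anilino ring: solubility notes

A few compounds are considered here, and "the series" means these few. Any claim that something is new, unique, unknown or untested is made for them only; others in the source may bear on it.

Measured so far in a physicochemical assay for solubility, at pH 7; a higher number here means a more soluble compound, a lower number a less soluble compound:
compound 1, `CNC(=O)c1cc(Oc2ccc3nc(Nc4cccc(C(C)(C)C)c4)ncc3c2)ccn1` — compound 1 gives < 1000 nM, a limit of the assay.
compound 2, `CNC(=O)c1cc(Oc2ccc3nc(Nc4ccccc4Br)ncc3c2)ccn1` — compound 2 gives < 1000 nM, a limit of the assay.
compound 3, `CNC(=O)c1cc(Oc2ccc3nc(Nc4cccc(Cl)c4)ncc3c2)ccn1` — compound 3 gives < 1000 nM, a limit of the assay.

Compound 3 stands where the other two stand: all three values shown sit at the limit of < 1000 nM in this assay, at which 3 of the 3 values shown sit, and none of them is a number. The steps among them are therefore unreadable: a step that the two limits leave unreadable from compound 1 to compound 3, a step that the two limits leave unreadable from compound 2 to compound 3 and a step that the two limits leave unreadable from compound 1 to compound 2 tell nothing about size or direction, only that neither end of each step rose above the limit.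

Compound 4, `CNC(=O)c1cc(Oc2ccc3nc(Nc4cccc(Br)c4)ncc3c2)ccn1`, differs from compound 3 by bromo in place of chloro on an aromatic carbon. Within the data shown here, no measured step bears directly on this swap; the only steps that touch the anilino ring are the unreadable ones above, and none of them moved a compound off the limit. The change is one heavy atom for one heavy atom, with no ring, donor, acceptor or charge added or removed, so no basis is seen for a readable step in this assay.

Compound 4 is therefore expected to report at the same limit, with an estimated step that the limit leaves unreadable from compound 3 to compound 4 that cannot be read, and an expected value of 400 nM (range 80 nM to 1500 nM).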

Compound 4, solubility: < 1000 nM
Compound 4 was reported as a limit; the forecaster's own chance of this, stated with the estimate: 85%; the middle value does not contradict the limit.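

In this assay compound 4 gives < 1000 nM, a limit of the assay. No new step can be read, since the steps from compound 1, compound 2 and compound 3 to compound 4 all join limits and show neither size nor direction. The compounds shown leave open where the true values of all four lie, and whether any of these substituent changes alters the read-out.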